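The source may hold more compounds than are shown below. What is called first, only, known or untested is meant among the compounds shown, and "the series" means these compounds.

Compound 1 `CSCC[C@H](NC(=O)c1ccc(NCc2cncn2Cc2cccc(Cl)c2)cc1-c1ccccc1)C(=O)O` gives > 10 uM in a functional assay on NIH3T3 cells (Mus musculus) (on this read-out higher numbers stand for an effect only at larger amounts of compound and lower numbers for an effect already at smaller amounts), a limit of the assay rather than a number. Compound 2 `CSCC[C@H](NC(=O)c1ccc(NCc2cncn2Cc2ccccc2Cl)cc1-c1ccccc1)C(=O)O` gives > 10 uM in this assay, again only a limit. Compound 3 `COC(=O)[C@H](CCSC)NC(=O)c1ccc(NCc2cncn2Cc2cccc(Cl)c2)cc1-c1ccccc1` gives > 10 uM in this assay, also a limit.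

Compound 1 and compound 2 differ in one place: 2-chlorophenyl in place of 3-chlorophenyl on a saturated chain carbon bound to an aromatic nitrogen. The step that the two limits leave unreadable from compound 1 to compound 2 cannot be sized, since both ends are limits. Compound 4 `COC(=O)[C@H](CCSC)NC(=O)c1ccc(NCc2cncn2Cc2ccccc2Cl)cc1-c1ccccc1` carries the same change on the core of compound 3: 2-chlorophenyl in place of 3-chlorophenyl on a saturated chain carbon bound to an aromatic nitrogen. The two cores differ by methyl in place of hydrogen on an oxygen next to a carbonyl group, and the place of the change is the same in both pairs, so this is the same change. Because the limit of > 10 uM in this assay, at which 3 of the 3 values shown sit, holds for every measured value, the step that the limit leaves unreadable from compound 3 to compound 4 is expected to be small and unreadable in the same way. Compound 4 is therefore estimated at 20 uM, most likely returned as a limit again.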

Compound 4, concentration for half-maximal effect: > 10 uM
Compound 4: no number, only a limit; the forecaster's own chance of this, stated with the estimate: 85%; the middle value does not contradict the limit.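

No step can be read from compound 2 or compound 3 to compound 4, because each value is only a limit of the assay: the limit of > 10 uM in this assay, at which 4 of the 4 values shown sit.

The compounds shown leave open whether 2-chlorophenyl and 3-chlorophenyl, or methyl and hydrogen on that oxygen, differ at all in this assay.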